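Phenyl for methyl on the fused core

The compounds below may be only part of what the source reports. "The series", "measured", "known", "first", "only" and "open" are said of these compounds alone.

Of the compounds shown here, three of a shared core have been measured in a functional assay on COLO 205 cells (Homo sapiens) for antiproliferative activity, read by MTT assay, with a stated time of 68 h; a higher number here means a weaker inhibitor, a lower number a stronger inhibitor. Compound 1 `O=S(=O)(Nc1ccc(F)c(C#Cc2cnc3[nH]ncc3c2)c1F)c1cccnc1` gives 445 nM. Compound 2 `COc1n[nH]c2ncc(C#Cc3c(F)ccc(NS(=O)(=O)c4cccnc4)c3F)cc12` gives 89 nM, and compound 3 `Cc1n[nH]c2ncc(C#Cc3c(F)ccc(NS(=O)(=O)c4cccnc4)c3F)cc12` gives 148 nM. Compound 3 stands second highest of the three numbers: its nearest neighbour is compound 2, a step of a 1.7-fold higher number from compound 2 to compound 3 (0.22 log units; within the scatter), within the scatter, while compound 1 is furthest, at a 3.0-fold lower number from compound 1 to compound 3 (0.48 log units; beyond the scatter). The parallel change to methoxy, a 5.0-fold lower number from compound 1 to compound 2 (0.70 log units; beyond the scatter), ran the same way.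

Compound 4 `O=S(=O)(Nc1ccc(F)c(C#Cc2cnc3[nH]nc(-c4ccccc4)c3c2)c1F)c1cccnc1` carries the change (phenyl in place of methyl on an aromatic carbon). Among the measured compounds shown here, only the steps from hydrogen to methyl and to methoxy bear on it, both modest and both toward lower numbers, and nothing measured shows how a group of this size behaves at that carbon. The expectation therefore rests on little: compound 4 is expected near compound 3, a step of a 1.4-fold higher number from compound 3 to compound 4 (0.13 log units; within the scatter), with a wide range. Compound 4 is estimated at 200 nM, between 60 nM and 700 nM.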

Compound 4, half-maximal inhibitory concentration: 200 nM
Estimate against measurement, compound 4: no gap at the digits printed; the range from low to high includes it.
By their numbers in this assay, from the lowest: compounds 2, 3 and 4 (each within the scatter of the next, the first and the last beyond it); then compound 1.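

In this assay the carbon of the five-membered ring accepts a phenyl and still keeps an advantage over hydrogen, with a 2.2-fold lower number from compound 1 to compound 4 (0.35 log units; beyond the scatter) as the step. Set against methyl, the exchange gives a 1.4-fold higher number from compound 3 to compound 4 (0.13 log units; within the scatter) and so does not separate the two groups, while set against methoxy it gives a 2.2-fold higher number from compound 2 to compound 4 (0.35 log units; beyond the scatter) and phenyl falls modestly short of that group. No measurement at hand accounts for these steps.

As far as these compounds go, whether an amine, a carboxylic acid or a longer chain such as butyl at this carbon would fit the same narrow span remains open. So does whether a phenyl carrying its own methoxy group would bring the number closer to that of compound 2 89 nM or move it further away.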